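Fixing One Stereocentre in a Cell-Killing Compound

This account rests on a few compounds, and the source may have more. Where it says the series, first, only, none or still open, it means among the compounds named here.

In a functional assay on Hep 3B2 cells (Homo sapiens) for cytotoxicity, read by MTT assay (a lower number here means a stronger inhibitor, a higher number a weaker inhibitor), compound 1 `CC1(C)C=Cc2c([C@H]3CCc4ccc(O)cc4O3)ccc(O)c2O1` gives 63600 nM, compound 2 `CC1(C)C=Cc2c(C3CCc4ccc(O)cc4O3)ccc(O)c2O1` gives 57400 nM and compound 3 `CC1(C)CCc2c([C@H]3CCc4ccc(O)cc4O3)ccc(O)c2O1` gives 41700 nM. Compound 2 therefore stands among numbers that all lie within the scatter of one another, so this small set offers no clear ranking.

The next compound to be tested is compound 4 `CC1(C)C=Cc2c([C@@H]3CCc4ccc(O)cc4O3)ccc(O)c2O1`. Its difference from compound 2 is purely one of how the structure is drawn in space: the two compounds have the same atoms and bonds; at least one stereo element is drawn with a configuration in one of them and without one in the other: 1 of 1 stereo elements differ; a stereocentre at a saturated ring carbon is drawn without a configuration in compound 2 and S in compound 4. Compound 1 carries the R drawing at that same saturated ring carbon, so it offers the closest comparison.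

Within the data shown here, the one measured step that bears on this change is a 1.1-fold lower number from compound 1 to compound 2 (0.04 log units; within the scatter). Among the measured compounds shown here, the sole difference behind that step is the fact that one of compounds 1 and 2 is drawn with a defined configuration and the other without, at the place where they differ. Since defining the centre as R in compound 1 left the number within the scatter of compound 2, the S drawing is not expected to produce a large change either, although the R result cannot settle this. The expected change is a 1.1-fold lower number from compound 2 to compound 4 (0.04 log units; within the scatter), which is no step beyond the scatter. For compound 4 the estimated value is 52000 nM, with an expected range from 29000 nM to 92000 nM.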

Compound 4, half-maximal inhibitory concentration: 75700 nM
Compound 4: middle estimate off by 1.5-fold (0.16 log units), on the low side; low and high end bracket the measured number.
By their numbers in this assay, from the lowest: compounds 3, 2, 1 and 4 (each within the scatter of the next).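

Among these compounds, with compound 4, both drawn configurations at this saturated ring carbon can be compared directly for the first time, and in this assay the comparison of R with S is a 1.2-fold higher number from compound 1 to compound 4 (0.08 log units; within the scatter). One thing alone lies behind this step: the fact that compounds 1 and 4 differ only in the configuration as drawn. The comparison of the undefined drawing with the S drawing, a 1.3-fold higher number from compound 2 to compound 4 (0.12 log units; within the scatter), agrees with it, so in these compounds neither defined configuration can be told apart from the undefined drawing or from the other configuration, as every gap stays within the normal scatter of repeated measurements.

As far as these compounds go, whether the configuration at this carbon would matter once a different group, such as an amine or a carboxylic acid, is attached to the shared core remains open. It also remains open whether any such group would give a number clearly separated from those of these compounds.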